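A Chain Double Bond on a Weak Thromboxane Receptor Antagonist

The source may report more compounds than this note shows. Statements on the series, on what has been measured and on what is new or still open speak of the compounds shown alone.

compound 1 `O=C(O)CC/C=C\C[C@H]1[C@H](F)CC[C@@H]1NS(=O)(=O)c1ccccc1[N+](=O)[O-]`: 560 nM
compound 2 `O=C(O)CCCCCC[C@@H]1[C@@H](CNS(=O)(=O)c2ccc(F)cc2)CC[C@H]1F`: 6000 nM

In a functional assay on a cell-free system (plasma) for inhibition of thromboxane A2 receptor (Homo sapiens), read by turbidimetry (on this read-out lower numbers stand for stronger inhibition and higher numbers for weaker inhibition), compound 1 gives 560 nM and compound 2 gives 6000 nM. Compound 2 thus stands at the higher of the two numbers, and its gap to compound 1 lies beyond the scatter. Compound 3 `O=C(O)CCC/C=C\C[C@@H]1[C@@H](CNS(=O)(=O)c2ccc(F)cc2)CC[C@H]1F` differs from compound 2 by 5-carboxypent-1-en-1-yl in place of 5-carboxypentyl on a saturated chain carbon bound to a saturated ring carbon. Among the measured compounds shown here, no step of this kind has been measured here, so the direction is estimated rather than known. Compound 3 is expected to give a lower number than compound 2, a step of a 4.0-fold lower number from compound 2 to compound 3 (0.60 log units; beyond the scatter), because compound 1, whose chain also carries a double bond, gives 560 nM. Compound 3 is estimated at 1500 nM, within 300 nM to 7000 nM.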

Compound 3, half-maximal inhibitory concentration: 2000 nM
Estimate against measurement, compound 3: 1.3-fold (0.12 log units) below; low and high end bracket the measured number.
By their numbers in this assay, from the lowest: compound 1; then compound 3; then compound 2.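

In this assay, 5-carboxypent-1-en-1-yl in place of 5-carboxypentyl on a saturated chain carbon bound to a saturated ring carbon gives a 3.0-fold lower number from compound 2 to compound 3 (0.48 log units; beyond the scatter) as a modest change. Among the compounds shown here, this is the first comparison in which the chain differs and the rest of the structure stays the same, so it shows that this one double bond alone shifts the number beyond the scatter. As far as these compounds go, whether a longer chain, or an amide in place of the carboxylic acid, would shift the number further remains open. Nothing shown here explains the step.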